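The source may hold more compounds than are shown below. What is called first, only, known or untested is meant among the compounds shown, and "the series" means these compounds.

Measured so far:
compound 1 `C=C(CC)C(=O)c1ccc(OCC(=O)Nc2ccc3c(c2)C(=O)NC3=O)c(Cl)c1Cl`: 2500 nM
compound 2 `C=C(CC)C(=O)c1ccc(OCC(=O)NC(CS)C(=O)OCC)c(Cl)c1Cl`: 4800 nM

In a functional assay on CLL cells (Homo sapiens) for cytotoxicity, read by MTT assay, with a stated time of 48 h (a lower number here means that less compound is needed, a higher number that more compound is needed for the effect), compound 2 gives 4800 nM, the higher of the two numbers here; compound 1 gives 2500 nM, and the two lie within the scatter of each other. Compound 3 `C=C(CC)C(=O)c1ccc(OCC(=O)Nc2ccc(C#N)cc2)c(Cl)c1Cl` is not yet measured. It differs from compound 2 by 4-cyanophenyl in place of 1-(ethoxycarbonyl)-2-sulfanylethyl on an amide-type nitrogen. For the measured compounds named here, no measured pair shows this change, so the expected step is a 1.7-fold lower number from compound 2 to compound 3 (0.23 log units; within the scatter), a modest drop in the number, not clearly beyond the scatter. Compound 3 is estimated at 2800 nM, with a range of 1000 nM to 8000 nM.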

Compound 3, half-maximal effective concentration: 7800 nM
Compound 3: middle estimate off by 2.8-fold (0.44 log units), on the low side; the measured number falls inside the stated range.
By their numbers in this assay, from the lowest: compounds 1, 2 and 3 (each within the scatter of the next, the first and the last beyond it).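

At the amide-type nitrogen, 4-cyanophenyl can take the place of the ring-free 1-(ethoxycarbonyl)-2-sulfanylethyl with a 1.6-fold higher number from compound 2 to compound 3 (0.21 log units; within the scatter) in this assay and no shift beyond the scatter. Neither the sulfanyl-bearing ester chain nor the aromatic ring is therefore required at this place for a number in this range. Nothing on hand explains the step.

Still open, as far as these compounds go, is whether a carboxylic acid in place of the ethyl ester would move the number beyond the scatter. The same question stands for a simple amine chain on that nitrogen.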